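Swapping the Heteroaromatic Ring on a Long-Chain Ketone

The source may report more compounds than this note shows. Statements on the series, on what has been measured and on what is new or still open speak of the compounds shown alone.

Compound 1, `CCCCCCCC/C=C\CCCCCCC(=O)c1nc2cnccc2o1`: in an assay on isolated protein for inhibition of Fatty-acid amide hydrolase 1 (Homo sapiens) (a higher number here means a weaker inhibitor, a lower number a stronger inhibitor), compound 1 gives 7.2 nM.
Compound 2, `CCCCCCCCCCCCCCCCCC(=O)C(F)(F)F`: in this assay compound 2 gives 240 nM.
Compound 3, `CCCCCCCC/C=C\CCCCCCC(=O)c1nc(-c2ccccc2)c(-c2ccccc2)o1`: in this assay compound 3 gives > 100000 nM, which is a limit of the assay and not a number.

Among the two compounds with a numerical value, compound 1 has the lowest number, and so is the stronger inhibitor of the pair; compound 2 is the nearest, and its number is higher by a margin that lies well beyond the usual scatter. Compound 3 sits at the limit of > 100000 nM in this assay, at which 1 of the 3 values shown sits.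

Compound 4 is `CCCCCCCC/C=C\CCCCCCC(=O)c1nccn1C`. It keeps the long unsaturated chain and the ketone of compound 1 but changes the ring on the carbonyl carbon: a group of 6 heavy atoms (4 carbon, 2 nitrogen; one five-membered aromatic ring with 2 hetero atoms) in place of a group of 9 heavy atoms (6 carbon, 2 nitrogen, 1 oxygen; one five-membered aromatic ring with 2 hetero atoms, one six-membered aromatic ring with 1 hetero atom), on a carbonyl carbon. Going by the values given here, no pair of measured compounds differs in just this way, so the size of the step has to be guessed from the structures alone. The expectation is that the number rises, by a step larger than the scatter, so that compound 4 is a weaker inhibitor than compound 1, a step of a 280-fold higher number from compound 1 to compound 4 (2.44 log units; beyond the scatter). Compound 4 is accordingly estimated at 2000 nM, with a likely range from 300 nM to 15000 nM.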

Compound 4, inhibition constant: > 100000 nM
Compound 4 was reported as a limit (the forecaster's own chance of this, stated with the estimate: 5%); middle value at least 50-fold (1.69 log units) from the limit.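

A ring change on this carbonyl carbon has now twice left a compound at the top of the measurable range, once in compound 3 and once in compound 4: the limit of > 100000 nM in this assay, at which 2 of the 4 values shown sit.

Replacing the group in compound 1 with the smaller 1-methyl-1H-imidazol-2-yl, while keeping the long unsaturated chain and the ketone unchanged, gives an at least 13000-fold higher number from compound 1 to compound 4 (4.14 log units; beyond the scatter) in this assay, so this single position can decide between strong inhibition and no measurable number. Compound 4 gives > 100000 nM, which is a limit of the assay and not a number.

The whole group changes in this one step, so the compounds shown do not reveal which part of it matters: the methyl on the new ring, the loss of the six-membered ring, or the change of ring atoms. An imidazol-2-yl group without the methyl, or the group of compound 1 carrying a carboxylic acid, would help separate these possibilities and show how much change this position tolerates.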